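Halogen swap on the nitrophenyl ring of compound 2

The source may hold more compounds than are shown below. What is called first, only, known or untested is meant among the compounds shown, and "the series" means these compounds.

Measured compounds in a functional assay on DU-145 cells (Homo sapiens) for inhibition, read by trypan blue exclusion, with a stated time of 96 h; a lower number here means a stronger inhibitor of growth, a higher number a weaker inhibitor of growth:
compound 1 `O=C(/C(=C\c1ccc(O)cc1O)SCc1cccc(Cl)c1)c1ccc(Br)cc1` gives 50000 nM
compound 2 `O=C(/C(=C\c1ccc(Cl)c([N+](=O)[O-])c1)S(=O)(=O)c1ccc(Br)cc1)c1ccc(Br)cc1` gives 10000 nM
compound 3 `O=C(/C(=C\c1ccc(Cl)c([N+](=O)[O-])c1)Sc1ccc(Br)cc1)c1ccc(Br)cc1` gives 10000 nM

Compound 2 stands level with compound 3 at the digits shown, and the two together give the lowest numbers of the three. Compound 1 sits furthest from compound 2, with a higher number, beyond the scatter. Among the compounds with values here, the one step between compounds that differ in a single place, no change at the digits printed from compound 2 to compound 3 (within the scatter), shows that swapping the sulfonyl for the sulfanyl linker at the chain carbon left the number unchanged within the scatter.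

Compound 4 `O=C(/C(=C\c1ccc(Br)c([N+](=O)[O-])c1)S(=O)(=O)c1ccc(Br)cc1)c1ccc(Br)cc1` is not yet measured. It differs from compound 2 by bromo in place of chloro on an aromatic carbon.

Within the data shown here, no measured step touches this halogen position; the only measured step concerns the linker, not the ring bearing the nitro group. Nothing in the series therefore speaks for a shift in either direction, and the expectation rests on compound 2 alone. The estimate for compound 4 in this assay is 10000 nM, with a range from 5000 nM to 20000 nM, which means an expected step of no change at the digits printed from compound 2 to compound 4 (within the scatter), within the scatter.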

Compound 4, concentration for 50% growth inhibition: 10000 nM
Compound 4: middle estimate and measured number agree at the digits printed, within the range that was stated.
By their numbers in this assay, from the lowest: compounds 2, 3 and 4 (each within the scatter of the next); then compound 1.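

In this assay, the step from 4-chloro-3-nitrophenyl to 4-bromo-3-nitrophenyl reads no change at the digits printed from compound 2 to compound 4 (within the scatter), so on this aromatic carbon, ortho to a nitro group and para to a large group, bromo and chloro cannot be told apart in the sulfonyl-linked compounds. This is the first reading on the ring bearing the nitro group, as the earlier single-place step concerned only the linker at the chain carbon; both single-place changes now shown stay within the scatter, a statement limited to compounds 2, 3 and 4. No measurement on hand explains why the two halogens read alike.

The compounds shown leave open whether this carbon accepts a group other than a halogen, such as an amine, a carboxylic acid or a methoxy group, and whether any of these would move the number beyond the scatter in either direction. Also open, on these data alone, is whether bromo and chloro would read alike on the sulfanyl-linked compound 3, and whether the neighbouring nitro group could give way to a nitrile without a shift in growth inhibition.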